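Methoxy for methyl on the second core

The source may hold more compounds than are shown below. What is called first, only, known or untested is meant among the compounds shown, and "the series" means these compounds.

Measured so far:
compound 1 `Cc1ccc(C(=O)C(=C2NCCN2)c2c(Cl)c(Cl)c(C#N)c(Cl)c2C#N)cc1`: 15.7 ug/mL
compound 2 `Cc1ccc(C(=O)C(=C2NCCN2)c2c(Cl)c(F)c(C#N)c(F)c2C#N)cc1`: 0.03 ug/mL
compound 3 `COc1ccc(C(=O)C(=C2NCCN2)c2c(Cl)c(Cl)c(C#N)c(Cl)c2C#N)cc1`: 2.3 ug/mL

Three compounds have been run in a functional assay on HL-60 cells (Homo sapiens) for antiproliferative activity, read by MTT assay; on this read-out higher numbers stand for weaker inhibition and lower numbers for stronger inhibition. Compound 1 gives 15.7 ug/mL and compound 3 gives 2.3 ug/mL; the two share a core and differ only in this way: methoxy in place of methyl on an aromatic carbon That change made the step of a 6.8-fold lower number from compound 1 to compound 3 (0.83 log units; beyond the scatter).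

Compound 2 gives 0.03 ug/mL in this assay, the lowest half-maximal inhibitory concentration of the three, beyond the scatter from both others. The difference between the core of compound 2 and the core of compound 1 is not broken down here.

Compound 4 `COc1ccc(C(=O)C(=C2NCCN2)c2c(Cl)c(F)c(C#N)c(F)c2C#N)cc1` is not yet measured. Among the compounds with values here, it differs from compound 2 as follows: methoxy in place of methyl on an aromatic carbon This is the same change as the one from compound 1 to compound 3, made at the same kind of place. For compound 4 a step like a 3.0-fold lower number from compound 2 to compound 4 (0.48 log units; beyond the scatter) is expected in this assay. That step is expected to be smaller than the earlier one because compound 2 already gives 0.03 ug/mL, which leaves little room for a lower number. Compound 4 is thus estimated at 0.01 ug/mL, with a likely range from 0.002 ug/mL to 0.06 ug/mL.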

Compound 4, half-maximal inhibitory concentration: 0.05 ug/mL
Beside the measured number, compound 4's estimate is 5.0-fold (0.70 log units) below it; the range from low to high includes it.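

Methoxy in place of methyl on the second core gives a 1.7-fold higher number from compound 2 to compound 4 (0.22 log units; within the scatter) in this assay, so this pair cannot be told apart on this read-out. The change does not carry its size from one core to the other: the same change on two cores in this assay, a 6.8-fold lower number (0.83 log units; beyond the scatter) from compound 1 to compound 3 and a 1.7-fold higher number (0.22 log units; within the scatter) from compound 2 to compound 4, 11-fold (1.06 log units) apart, beyond the scatter of two such steps. This shows that the lower number seen on the core of compound 1 cannot be assumed on another core in this series, but it does not show what in the two cores sets the steps apart, and one pair per core gives no rule for a third core.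

The cores differ in more than one atom, so the compounds shown leave open which of the chlorine or fluorine atoms the size of the step depends on. Also open, on these data alone, is how an amine or a carboxylic acid in place of the methoxy would behave on either core, and whether any such step would again differ between them.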